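The source may report more compounds than this note shows. Statements on the series, on what has been measured and on what is new or still open speak of the compounds shown alone.

Measured so far:
compound 1, `CC(C)[C@@H](NC(=O)c1cc2ccccc2s1)C(=O)N1CCC(c2ccc(Cl)cc2)CC1`, an assay on THP-1 cells for displacement of a labelled ligand from C-C chemokine receptor type 1 (Homo sapiens) (on this read-out higher numbers stand for weaker inhibition and lower numbers for stronger inhibition), 58 nM
compound 2, `CC(C)C(NS(=O)(=O)Cc1ccccc1)C(=O)N1CCC(c2ccc(Cl)cc2)CC1`, this assay 303 nM
compound 3, `CC[C@@H](C)[C@@H](NC(=O)CC(C)C)C(=O)N1CCC(c2ccc(Cl)cc2)CC1`, this assay 34 nM

Among these three numbers compound 1 stands second highest. Its nearest neighbour is compound 3, whose value lies within the usual scatter of compound 1, so no order between the two can be read. Compound 2 is furthest away, with a value beyond the scatter and clearly weaker than compound 1.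

The step to be followed is from compound 1 to compound 4, `Cc1cccc(CCC(=O)N[C@@H](C(=O)N2CCC(c3ccc(Cl)cc3)CC2)C(C)C)c1`. The change is 2-(3-methylphenyl)ethyl in place of 1-benzothiophen-2-yl on a carbonyl carbon. Going by the values given here, no measured step of this kind is available, so only a general expectation can be given. Compound 3 gives 34 nM in this assay although it carries no 1-benzothiophen-2-yl group, which suggests that the amide side of the shared core accepts other groups without a large loss. For compound 4 a step of a 1.0-fold higher number from compound 1 to compound 4 (0.01 log units; within the scatter) is expected, that is none beyond the scatter. Compound 4 is therefore estimated at 60 nM, within 25 nM to 150 nM.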

Compound 4, half-maximal inhibitory concentration: 22 nM
Estimate against measurement, compound 4: 2.7-fold (0.44 log units) above; measured number outside the range, below it.
By their numbers in this assay, from the lowest: compounds 4, 3 and 1 (each within the scatter of the next, the first and the last beyond it); then compound 2.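

In this assay, going by these compounds alone, 2-(3-methylphenyl)ethyl in place of 1-benzothiophen-2-yl on a carbonyl carbon gives a 2.6-fold lower number from compound 1 to compound 4 (0.42 log units; beyond the scatter), a modest gain in inhibition and the first direct reading of a change at this place. With the same number of heavy atoms on each side of the change, this pair shows that neither the sulfur nor the five-membered aromatic ring of 1-benzothiophen-2-yl is required for inhibition at this level, and that one six-membered aromatic ring on an ethyl chain serves at least as well. No measurement available here bears on why the step goes this way.

Still open, from the compounds shown here alone, is how much of the step belongs to the methyl group and how much to the ethyl chain. Plain 2-phenylethyl, benzyl and 3-phenylpropyl at this place would separate the two.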